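Dichlorophenyl Analogue in a HeLa Cytotoxicity Series

The source may hold more compounds than are shown below. What is called first, only, known or untested is meant among the compounds shown, and "the series" means these compounds.

Measured compounds:
- compound 1, `O=C(/C=C\c1ccc(O)cc1)N1N=C(c2ccncc2)OC1c1c[nH]c2ccccc12`, gives in an ADME assay on HeLa cells (Homo sapiens) for cytotoxicity, read by MTT assay, with a stated time of 72 h (a higher number here means a weaker inhibitor of growth, a lower number a stronger inhibitor of growth), only a limit, > 30 ug/mL.
- compound 2, `O=C(/C=C\c1ccccc1[N+](=O)[O-])N1N=C(c2ccncc2)OC1c1c[nH]c2ccccc12`, gives in this assay only a limit, > 30 ug/mL.
- compound 3, `O=C(/C=C\c1ccc([N+](=O)[O-])cc1)N1N=C(c2ccncc2)OC1c1c[nH]c2ccccc12`, gives in this assay only a limit, > 30 ug/mL.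

Compound 1 therefore stands nowhere in particular on the numbers: its value is a limit, and the two further values are limits as well. The measured steps, a step that the two limits leave unreadable from compound 1 to compound 2, a step that the two limits leave unreadable from compound 1 to compound 3 and a step that the two limits leave unreadable from compound 2 to compound 3, are all unreadable for the same reason, since every compound sits at the limit of > 30 ug/mL in this assay, at which 3 of the 3 values shown sit. None of them shows whether the aryl group on the chain moves the growth inhibition at all.

Compound 4, `O=C(/C=C\c1ccc(Cl)cc1Cl)N1N=C(c2ccncc2)OC1c1c[nH]c2ccccc12`, differs from compound 1 in one place: 2,4-dichlorophenyl in place of 4-hydroxyphenyl on a double-bonded chain carbon bound to a double-bonded chain carbon. For the measured compounds named here, the steps that bear on this change, 2-nitrophenyl or 4-nitrophenyl in place of 4-hydroxyphenyl, give no readable size, so no direction beyond the scatter can be drawn from them; the only expectation is that compound 4 again falls at the limit rather than at a number. Compound 4 is therefore estimated at 45 ug/mL, with a range from 15 ug/mL to 120 ug/mL. The expected step from compound 1 is a step that the limit leaves unreadable from compound 1 to compound 4.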

Compound 4, concentration for 50% growth inhibition: 29.3 ug/mL
Beside the measured number, compound 4's estimate is 1.5-fold (0.19 log units) above it; the range from low to high includes it.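

For the compounds shown here, with 2,4-dichlorophenyl on a double-bonded chain carbon bound to a double-bonded chain carbon, compound 4 is the first compound here to give a number rather than a limit in this assay, so this position can hold a group for which growth inhibition is read as a value, 29.3 ug/mL. The change can still be sized only by floors: an at least 1.0-fold lower number from compound 1 to compound 4 (0.01 log units; that floor lies within the scatter), an at least 1.0-fold lower number from compound 3 to compound 4 (0.01 log units; that floor lies within the scatter) and an at least 1.0-fold lower number from compound 2 to compound 4 (0.01 log units; that floor lies within the scatter), so the data do not establish that the 2,4-dichlorophenyl group gives stronger growth inhibition than 4-hydroxyphenyl, 4-nitrophenyl or 2-nitrophenyl. The steps among compound 1, compound 2 and compound 3 remain unreadable, and the true distance from each of them to compound 4 stays hidden: the limit of > 30 ug/mL in this assay, at which 3 of the 4 values shown sit.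

The compounds shown leave open whether a 4-chlorophenyl group, an unsubstituted phenyl group or a 4-aminophenyl group at this place would also give a number, and so whether both chlorine atoms matter. They also leave open whether a value well clear of the limit can be reached at this position at all.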